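Sulfonyl substituent and solubility in the urea series

This account rests on a few compounds, and the source may have more. Where it says the series, first, only, none or still open, it means among the compounds named here.

Measured compounds:
Compound 1 `O=C(NCc1ccc(S(=O)(=O)c2cccc(C(F)(F)F)c2)cc1)N1Cc2ccncc2C1`: 10000 nM
Compound 2 `O=C(NCc1ccc(S(=O)(=O)N2CCC(O)CC2)cc1)N1Cc2ccncc2C1`: 174000 nM
Compound 3 `CN1CCN(S(=O)(=O)c2ccc(CNC(=O)N3Cc4ccncc4C3)cc2)CC1`: 160000 nM

All three share one core and differ only in the group on the sulfonyl sulfur. In a physicochemical assay for solubility, in phosphate buffer, with a stated time of 24 h, at pH 7.4, tested at 100 uM (a lower number here means a less soluble compound, a higher number a more soluble compound), compound 1 stands lowest of the three numbers; compound 3 is nearest and compound 2 furthest, and both gaps lie beyond the scatter.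

Compound 4 `O=C(NCc1ccc(S(=O)(=O)N2CC3(CCOCC3)C2)cc1)N1Cc2ccncc2C1` is the next member. Relative to compound 1 the change is a group of 9 heavy atoms (7 carbon, 1 nitrogen, 1 oxygen; one four-membered non-aromatic ring with 1 hetero atom, one six-membered non-aromatic ring with 1 hetero atom) in place of a group of 10 heavy atoms (7 carbon, 3 fluorine; one six-membered aromatic ring of carbon only), on a sulfonyl sulfur.

For the measured compounds named here, two measured steps bear directly on this change, since each also removes the 3-(trifluoromethyl)phenyl from the sulfonyl sulfur in favour of a non-aromatic ring joined through nitrogen: a 17-fold higher number from compound 1 to compound 2 (1.24 log units; beyond the scatter) and a 16-fold higher number from compound 1 to compound 3 (1.20 log units; beyond the scatter). The step of a 1.1-fold lower number from compound 2 to compound 3 (0.04 log units; within the scatter) shows that the two non-aromatic rings measured so far give numbers within the scatter of each other. The entering group of compound 4 is again a non-aromatic, nitrogen-linked ring, here with one hydrogen-bond acceptor and no donor and no charge, so a large rise in this assay is expected because a 17-fold higher number from compound 1 to compound 2 (1.24 log units; beyond the scatter) and a 16-fold higher number from compound 1 to compound 3 (1.20 log units; beyond the scatter) were both large and in the same direction.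

Compound 4 is therefore estimated at 100000 nM in this assay, within a range of 40000 nM to 200000 nM. This estimate corresponds to an expected step of a 10-fold higher number from compound 1 to compound 4 (1.00 log units; beyond the scatter).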

Compound 4, solubility: 272000 nM
Compound 4: middle estimate off by 2.7-fold (0.43 log units), on the low side; measured number outside the range, above it.
By their numbers in this assay, from the lowest: compound 1; then compounds 3, 2 and 4 (each within the scatter of the next).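

In this assay, the group entering in compound 4, with its four-membered and six-membered non-aromatic rings, gives a third large step away from 3-(trifluoromethyl)phenyl on the sulfonyl sulfur (a 27-fold higher number from compound 1 to compound 4 (1.43 log units; beyond the scatter)). This step comes with an entering group of 0 hydrogen-bond donors, 1 hydrogen-bond acceptor and no net charge, so among the compounds shown a large step does not depend on a hydrogen-bond donor in the group. The two-ring group also stays within the scatter of both single-ring groups (a 1.7-fold higher number from compound 3 to compound 4 (0.23 log units; within the scatter); a 1.6-fold higher number from compound 2 to compound 4 (0.19 log units; within the scatter)), so the three non-aromatic groups are not separated in this read-out, and no measurement on hand accounts for the size of the step.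

The compounds shown leave open how an open-chain dimethylamino group, or a piperidine ring carrying a carboxylic acid, would stand on the sulfonyl sulfur, and whether an unsubstituted phenyl would sit close to compound 1 at 10000 nM in this assay. They also leave open whether the steps seen here carry over to a core other than the shared one.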